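The source may hold more compounds than are shown below. What is called first, only, known or untested is meant among the compounds shown, and "the series" means these compounds.

Working notes on the series. Compound 2 `COc1cc(NC(C)CCCNC(=O)NNC(=O)Nc2ccc(Br)cc2)c2ncccc2c1` gives 27000 nM in a functional assay on NCI-H460 cells (Homo sapiens) for inhibition, read by MTT assay, with a stated time of 72 h; on this read-out higher numbers stand for weaker inhibition and lower numbers for stronger inhibition. Among the three measured compounds it holds the highest number, but its neighbours sit close: compound 3 `COc1cc(NC(C)CCCNC(=O)Nc2ccc(C(F)(F)F)cc2)c2ncccc2c1` gives 24000 nM in this assay, and compound 1 `COc1cc(NC(C)CCCNC(=O)NNC(=O)Nc2cc(C(F)(F)F)cc(C(F)(F)F)c2)c2ncccc2c1` gives 18000 nM in this assay, both within the scatter of compound 2. Within the data shown here, the only single-point step measured so far, a 1.1-fold lower number from compound 2 to compound 3 (0.05 log units; within the scatter), exchanges the whole urea-linked aryl portion and still moves nothing beyond the scatter.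

Compound 4 `COc1cc(NC(C)CCCNC(=O)NNC(=O)Nc2cccc(Cl)c2)c2ncccc2c1` is to be measured in this assay. It differs from compound 2 by 3-chlorophenyl in place of 4-bromophenyl on an amide-type nitrogen. Among the measured compounds shown here, no measured pair isolates a change of halogen or of its position on that phenyl, so there is no direct precedent for this step. What the series does show is that replacing the aryl portion on this end of the molecule, whether by the step from compound 2 to compound 3 or by the bis(trifluoromethyl)phenyl of compound 1, leaves the number inside the scatter. On that basis no step beyond the scatter is expected from compound 2 to compound 4, a 1.1-fold lower number from compound 2 to compound 4 (0.03 log units; within the scatter). Compound 4 is therefore estimated at 25000 nM in this assay, with a range of 9000 nM to 70000 nM.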

Compound 4, half-maximal inhibitory concentration: 32000 nM
For compound 4 the middle estimate is 1.3-fold (0.11 log units) below the measured one; measured number inside the range.
By their numbers in this assay, from the lowest: compounds 1, 3, 2 and 4 (each within the scatter of the next).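

Among these compounds, the step of a 1.2-fold higher number from compound 2 to compound 4 (0.07 log units; within the scatter) in this assay is the first pair to alter the halogen and its place on the phenyl together, and the number stays within the scatter for this combined change on an amide-type nitrogen. The second step, a 1.3-fold higher number from compound 3 to compound 4 (0.12 log units; within the scatter), exchanges ((3-chlorophenyl)carbamoyl)amino for 4-(trifluoromethyl)phenyl on that nitrogen and also stays within the scatter, so the longer and the shorter end of the molecule are not told apart by this read-out, here with a different aryl group on each. No information is available that bears on why these numbers stay together.

On these data alone, the pair from compound 2 to compound 4 changes halogen and position at once, so the separate contributions of each remain open, and 4-chlorophenyl or 3-bromophenyl would divide them. Also open, as far as these compounds go, is whether this end of the molecule tolerates every change or only the halogen and trifluoromethyl aryl groups seen here, a question that a phenyl carrying an amine or a carboxylic acid, or a longer chain on the shared core, would test.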